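This account rests on a few compounds, and the source may have more. Where it says the series, first, only, none or still open, it means among the compounds named here.

Working notes on the series. Compound 3 `C=Cc1cc(C#Cc2ccc3ncn(-c4ccnc(N)n4)c3c2)ccn1` links the shared core through a triple bond to an aromatic ring carrying a vinyl group; compound 1 `C=CC(=O)NCCCc1ccc2ncn(-c3ccnc(N)n3)c2c1` and compound 2 `CC(=O)NCCCc1ccc2ncn(-c3ccnc(N)n3)c2c1` instead carry a chain ending in a carbonyl; compound 4 `C=Cc1ccnc(C#Cc2ccc3ncn(-c4ccnc(N)n4)c3c2)n1` keeps the triple-bond link of compound 3 with a different ring. In an assay on Sf9 cells for inhibition of mitogen-activated protein kinase kinase kinase 14 variant S549D (Homo sapiens), with a stated time of 30 min, in the presence of a further agent that is not named here (on this read-out lower numbers stand for stronger inhibition and higher numbers for weaker inhibition), compound 1 gives 501000 nM and compound 3 gives 20000 nM, so compound 3 stands lowest of the two numbers shown, its nearest neighbour being compound 1 at a gap beyond the scatter. In this assay compound 2 reports only a limit, > 100000 nM, not a number (the limit of > 100000 nM in this assay, at which 1 of the 3 values shown sits). Within the data shown here, the single one-place step, a step that the limit leaves unreadable from compound 1 to compound 2, cannot be sized because of the limit (the limit of > 100000 nM in this assay, at which 1 of the 3 values shown sits).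

The change to compound 4 is a group of 8 heavy atoms (6 carbon, 2 nitrogen; one six-membered aromatic ring with 2 hetero atoms) in place of a group of 8 heavy atoms (7 carbon, 1 nitrogen; one six-membered aromatic ring with 1 hetero atom), on a triple-bonded carbon. Among the measured compounds shown here, no measured step touches this triple-bonded position or this kind of ring exchange; the step from compound 1 to compound 2 concerns methyl in place of vinyl on a carbonyl carbon and yields no size. With nothing to set a direction, the expected step is none beyond the scatter, no change at the digits printed from compound 3 to compound 4 (within the scatter). Compound 4 is therefore estimated at 20000 nM, with a range from 5000 nM to 80000 nM.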

Compound 4, half-maximal inhibitory concentration: 1580 nM
For compound 4 the middle estimate is 13-fold (1.10 log units) above the measured one; measured number below the stated range.
By their numbers in this assay, from the lowest: compound 4; then compound 3; then compound 1.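

In this assay the group on the triple-bonded carbon proves able to move the number: exchanging the 2-vinylpyridin-4-yl group for a group of the same heavy-atom count, with a six-membered aromatic ring holding 2 hetero atoms, gives a 13-fold lower number from compound 3 to compound 4 (1.10 log units; beyond the scatter) in a large step beyond the scatter. Among these compounds, this is the first step that can be sized, and it shows that this position responds to a ring exchange even though the double bond outside the aromatic ring stays in both groups, something the earlier compounds could not show because they offered no measured step here. Nothing at hand bears on why this ring exchange gives so large a step.

Among the compounds shown here, the one step that touches a vinyl group, from compound 1 to compound 2, cannot be read, so what the vinyl group contributes on the ring of compound 4 stays open. Also open, from the compounds shown here alone, is how the number would respond to an ethyl group or an amine in that place, or to a longer chain in place of the triple-bond link, since a single ring exchange sets no trend.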